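The source may report more compounds than this note shows. Statements on the series, on what has been measured and on what is new or still open speak of the compounds shown alone.

Measured compounds:
Compound 1 `CCCNc1nc2ccccc2c(NCc2ccc(NC(=O)c3ccc(F)cc3)cc2)c1C#N`; in a functional assay on HCT-116 cells (Homo sapiens) for inhibition, read by luminescence and resazurin assay, with a stated time of 3 days (on this read-out higher numbers stand for weaker inhibition and lower numbers for stronger inhibition), compound 1 gives > 20000 nM, which is a limit of the assay and not a number.
Compound 2 `CCCNc1nc(NCc2ccc(NC(=O)c3ccc(F)cc3)cc2)c2ccccc2n1`; compound 2 gives 1700 nM.
Compound 3 `CN1CCN(c2nc(NCc3ccc(NC(=O)c4ccc(F)cc4)cc3)c3ccccc3n2)CC1`; compound 3 gives 1800 nM.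

Compound 1 stands only as the limit of > 20000 nM in this assay, at which 1 of the 3 values shown sits, so its inhibition is weaker than the assay can resolve. Compound 4 `CNc1nc2ccccc2c(NCc2ccc(NC(=O)c3ccc(F)cc3)cc2)c1C#N` differs from it by hydrogen in place of ethyl on a saturated chain carbon bound to a nitrogen on an aromatic ring. Going by the values given here, the single measured step, a 1.1-fold higher number from compound 2 to compound 3 (0.02 log units; within the scatter), swaps a group on a different core and does not speak to shortening a chain, so no measured step bears on this change. The expectation is therefore no step beyond the scatter, with compound 4 expected to remain as weak as compound 1, a step that the limit leaves unreadable from compound 1 to compound 4. Compound 4 is estimated at 30000 nM, in a range of 8000 nM to 100000 nM.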

Compound 4, half-maximal inhibitory concentration: > 20000 nM
Compound 4 ended at the assay's limit (the forecaster's own chance of this, stated with the estimate: 75%); the middle value is on the limit's open side.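

In this assay, going by these compounds alone, compound 4 gives > 20000 nM, which is a limit and not a number, and compound 1 also stands at a limit, so no step between them can be read. Going by these compounds, whether propylamino and methylamino differ at all in inhibition on this core stays open.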